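The source may hold more compounds than are shown below. What is called first, only, known or untested is meant among the compounds shown, and "the series" means these compounds.

In a functional assay on T98G cells (Homo sapiens) for cytotoxicity, read by MTT assay (on this read-out higher numbers stand for weaker inhibition and lower numbers for stronger inhibition), compound 1 `Oc1ccc(CN(Cc2ccccc2)Cc2ccc(O)c3ncccc23)c2cccnc12` gives 249 nM, compound 2 `Oc1ccc(CN(Cc2ccccc2C(F)(F)F)Cc2ccc(O)c3ncccc23)c2cccnc12` gives 210 nM and compound 3 `Oc1ccc(CN(Cc2cccs2)Cc2ccc(O)c3ncccc23)c2cccnc12` gives 88 nM. Compound 3 therefore has the lowest number of the three. The next structure, compound 4 `O=C(O)C1CCC(CN(Cc2ccc(O)c3ncccc23)Cc2ccc(O)c3ncccc23)CC1`, carries 4-carboxycyclohexyl in place of thiophen-2-yl on a saturated chain carbon bound to an amine nitrogen.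

Among the measured compounds shown here, the steps that bear on this change are a 2.8-fold lower number from compound 1 to compound 3 (0.45 log units; beyond the scatter) and a 2.4-fold lower number from compound 2 to compound 3 (0.38 log units; beyond the scatter), both of which bring in thiophen-2-yl at this place. The remaining step, a 1.2-fold lower number from compound 1 to compound 2 (0.07 log units; within the scatter), does not involve thiophen-2-yl and offers little guidance. For the measured compounds named here, no measured compound has a carboxy group or a non-aromatic ring at this place, so the size of the step is uncertain. Losing thiophen-2-yl is nevertheless expected to raise the number by a modest amount, returning it towards the values of the other two compounds. The expected step is a 3.4-fold higher number from compound 3 to compound 4 (0.53 log units; beyond the scatter). Compound 4 is estimated at 300 nM, with an expected range from 90 nM to 1000 nM.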

Compound 4, half-maximal inhibitory concentration: 9760 nM
The estimate for compound 4 lay 33-fold (1.51 log units) below the measured number; the measured number lies above the stated range.
By their numbers in this assay, from the lowest: compound 3; then compounds 2 and 1 (each within the scatter of the next); then compound 4.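

In this assay, 4-carboxycyclohexyl on a saturated chain carbon bound to an amine nitrogen gives a 110-fold higher number from compound 3 to compound 4 (2.04 log units; beyond the scatter) in place of thiophen-2-yl, a 46-fold higher number from compound 2 to compound 4 (1.67 log units; beyond the scatter) in place of 2-(trifluoromethyl)phenyl and a 39-fold higher number from compound 1 to compound 4 (1.59 log units; beyond the scatter) in place of phenyl. The earlier compounds shown here, all with an aromatic ring at this place, differed by modest steps at most, whereas these steps are large and show that the read-out at this place is far more sensitive to the group than those compounds revealed. Nothing shown here accounts for the size of this rise.

4-carboxycyclohexyl brings a non-aromatic ring and a carboxylic acid together, and the compounds shown do not separate the two. A plain cyclohexyl, or a phenyl ring bearing a carboxylic acid, at this place would tell them apart.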